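The source may hold more compounds than are shown below. What is called first, only, known or untested is meant among the compounds shown, and "the series" means these compounds.

Compound 1, `Cc1nc(NCC(C)C)nc(N[C@@H]2C[C@H](CO)[C@@H](O)[C@H]2O)c1-c1nc2ccccc2s1`, gives 10000 nM in an ADME assay on cells (Homo sapiens) for cytotoxicity, read by polymerase chain reaction, with a stated time of 3 days; on this read-out higher numbers stand for lower toxicity in this test and lower numbers for higher toxicity in this test. Compound 2, `Cc1nc(NCC2CC2)nc(N[C@@H]2C[C@H](CO)[C@@H](O)[C@H]2O)c1-c1nc2ccccc2s1`, gives 8000 nM in this assay. Compound 3, `COCCNc1nc(C)c(-c2nc3ccccc3s2)c(N[C@@H]2C[C@H](CO)[C@@H](O)[C@H]2O)n1`, gives 21000 nM in this assay.

All three share one core and differ only in the group on the saturated chain carbon bound to a nitrogen on the aromatic ring. Compound 3 stands highest of the three numbers: the nearest is a 2.1-fold higher number from compound 1 to compound 3 (0.32 log units; beyond the scatter), the furthest a 2.6-fold higher number from compound 2 to compound 3 (0.42 log units; beyond the scatter), while a 1.3-fold lower number from compound 1 to compound 2 (0.10 log units; within the scatter). Compound 4, `Cc1nc(NCCNS(C)(=O)=O)nc(N[C@@H]2C[C@H](CO)[C@@H](O)[C@H]2O)c1-c1nc2ccccc2s1`, keeps the chain of compound 3 and carries methanesulfonamido in place of methoxy on a saturated chain carbon, two bonds along the chain from a nitrogen on an aromatic ring.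

For the measured compounds named here, none of the measured steps covers this kind of group; they only show that swapping the end of this chain has moved this assay by modest amounts at most, with compound 3 already the highest. On that basis the step of a 1.2-fold higher number from compound 3 to compound 4 (0.08 log units; within the scatter) is expected to be small and, if anything, upward, with a fair chance of landing within the scatter. Compound 4 is therefore estimated at 25000 nM in this assay, with a range from 10000 nM to 60000 nM.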

Compound 4, half-maximal cytotoxic concentration: > 25000 nM
Compound 4 ended at the assay's limit; the forecaster's own chance of this, stated with the estimate: 25%; the middle value lies on the limit itself.
By their numbers in this assay, from the lowest: compounds 2 and 1 (each within the scatter of the next); then compound 3. At a limit, above all of these: compound 4.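

In this assay, compound 4 ends at a limit of the assay and not at a number: the limit of > 25000 nM in this assay, at which 1 of the 4 values shown sits.

The position therefore tolerates a much larger chain end, with methanesulfonamido bringing a sulfur, a nitrogen and a hydrogen-bond donor that methoxy lacks, and the number does not fall. Against the two chain ends with only carbon and hydrogen, the result is clear, with an at least 3.1-fold higher number from compound 2 to compound 4 (0.49 log units; beyond the scatter) and an at least 2.5-fold higher number from compound 1 to compound 4 (0.39 log units; beyond the scatter), so compound 4 joins compound 3 on the high side of compound 1 and compound 2. The change from methoxy is less certain, with an at least 1.1-fold higher number from compound 3 to compound 4 (0.07 log units; that floor lies within the scatter), so the result does not separate compound 4 from compound 3.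

On these data alone, since the true number for compound 4 lies somewhere past the limit, the size of the methoxy to methanesulfonamido step remains open. The compounds shown also leave open whether an amine or a carboxylic acid at the end of this chain, or a longer chain carrying the methanesulfonamido group, would keep the number this high.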